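Replacing the amide ring of compound 3 with a hexyl chain

This account rests on a few compounds, and the source may have more. Where it says the series, first, only, none or still open, it means among the compounds named here.

Measured in a functional assay on A549 cells (Homo sapiens) for inhibition, read by MTT assay, with a stated time of 48 h; a higher number here means a weaker inhibitor, a lower number a stronger inhibitor:
- compound 1 `COc1ccc(/C=C/c2cc(OC)cc(OC)c2/C=C/C(=O)N2CCCCC2C)cc1`: 5770 nM
- compound 2 `COc1ccc(/C=C/c2cc(OC)cc(OC)c2/C=C/C(=O)Nc2cc(OC)c(OC)c(OC)c2)cc1`: 5140 nM
- compound 3 `COc1ccc(/C=C/c2cc(OC)cc(OC)c2/C=C/C(=O)N2CCC(c3ccccc3)CC2)cc1`: 6690 nM

The three compounds share a core and differ only in the group on the carbonyl carbon. Their values all lie within the usual scatter of one another, so compound 3, at 6690 nM, stands level with the other two in this assay.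

The next compound is compound 4 `CCCCCCNC(=O)/C=C/c1c(/C=C/c2ccc(OC)cc2)cc(OC)cc1OC`, which carries hexylamino in place of 4-phenylpiperidin-1-yl on a carbonyl carbon.

Among the compounds with values here, only one measured step bears directly on this change. It is a 1.2-fold higher number from compound 1 to compound 3 (0.06 log units; within the scatter), a swap between two piperidine amides that stays within the scatter. Within the data shown here, no measured pair shows a ring amide giving way to an open chain, so this evidence is indirect. Compound 4 keeps the amide hydrogen, as does compound 2 at 5140 nM, and that value also sits with the others.

No shift beyond the scatter is therefore expected, and the expected change is a 1.2-fold lower number from compound 3 to compound 4 (0.09 log units; within the scatter). The range is kept wide, since no chain amide has been measured. For compound 4 the estimated value is 5500 nM, with an expected range of 2500 nM to 12000 nM.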

Compound 4, half-maximal inhibitory concentration: 6230 nM
Estimate against measurement, compound 4: 1.1-fold (0.05 log units) below, and the stated range covers the measured number.
By their numbers in this assay, from the lowest: compounds 2, 1, 4 and 3 (each within the scatter of the next).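

In this assay, within the data shown here, compound 4 brings the first group on this carbonyl carbon with no ring, and the open chain stands level with the ring amide (a 1.1-fold lower number from compound 3 to compound 4 (0.03 log units; within the scatter)). The same holds for the other two comparisons, with hexylamino in place of 2-methylpiperidin-1-yl (a 1.1-fold higher number from compound 1 to compound 4 (0.03 log units; within the scatter)) and hexyl in place of 3,4,5-trimethoxyphenyl on an amide-type nitrogen (a 1.2-fold higher number from compound 2 to compound 4 (0.08 log units; within the scatter)), so two piperidine amides, an aryl amide and a straight-chain amide all lie level across these four compounds. Nothing measured here accounts for why such different groups give matching numbers.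

The compounds shown leave open whether a hexyl chain ending in a dimethylamino group or a carboxylic acid, or a much shorter chain such as ethyl, would stand level with these four on the same carbonyl carbon. They also leave open whether this level picture would persist if the methoxy groups on the shared core gave way to hydroxy groups, since all four compounds carry the same core.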